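The source may report more compounds than this note shows. Statements on the series, on what has been measured and on what is new or still open speak of the compounds shown alone.

Measured compounds in an assay on HEK293 cells for displacement of a labelled ligand from C-X-C chemokine receptor type 3 (Homo sapiens); on this read-out higher numbers stand for weaker inhibition and lower numbers for stronger inhibition:
- compound 1 `CN(CC1=CC[C@H]2C[C@@H]1C2(C)C)Cc1ccccc1`: 15800 nM
- compound 2 `CN(CC1=CC[C@H]2C[C@@H]1C2(C)C)Cc1ccc(-c2ccccc2)cc1`: 3160 nM
- compound 3 `COC(=O)c1cccc(-c2ccc(CN(C)CC3=CC[C@H]4C[C@@H]3C4(C)C)cc2)c1`: > 316 nM

The value for compound 3 is a limit of this assay, not a number, so compound 3 cannot be placed against the others on the numbers shown; the step that the limit leaves unreadable from compound 2 to compound 3 is therefore not readable. Among the numbered values, the step of a 5.0-fold lower number from compound 1 to compound 2 (0.70 log units; beyond the scatter) is the only readable one in the set.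

Compound 4 `CC(=O)c1cccc(-c2ccc(CN(C)CC3=CC[C@H]4C[C@@H]3C4(C)C)cc2)c1` differs from compound 3 by methyl in place of methoxy on a carbonyl carbon. Among the measured compounds shown here, no measured step touches the carbonyl substituent, and the one readable step, from compound 1 to compound 2, concerns a much larger change on the aromatic ring. The change from methoxycarbonyl to acetyl is small, and a step within the usual scatter of this assay is expected. Compound 4 is therefore estimated at 2000 nM, with a range from 500 nM to 8000 nM. That estimate means an expected step that the limit leaves unreadable from compound 3 to compound 4.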

Compound 4, inhibition constant: > 316 nM
Compound 4 gave a limit, no number (the forecaster's own chance of this, stated with the estimate: 40%); the middle value lies beyond the limit too.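

No new step can be read for compound 4 against compound 1, compound 2 or compound 3, as compound 4 gives only a limit, shared with compound 3: the limit of > 316 nM in this assay, at which 2 of the 4 values shown sit.

Still open, on these data alone, is whether methyl in place of methoxy on the carbonyl carbon shifts the inhibition constant, and how compound 3 and compound 4 stand against compound 2.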